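Swapping a Cyclopentyl for a Hydroxypropyl Chain, Twice

The source may hold more compounds than are shown below. What is called first, only, known or untested is meant among the compounds shown, and "the series" means these compounds.

Compound 1 `COc1ccc(N(C)c2nc(NC3CCCC3)c3ccccc3n2)cc1` and compound 2 `COc1ccc(N(C)c2nc(NCCCO)c3ccccc3n2)cc1` share one core and differ in a single spot. In a functional assay on MV4-11 cells (Homo sapiens) for antiproliferative activity, read by MTT assay (a lower number here means a stronger inhibitor of growth, a higher number a weaker inhibitor of growth), compound 1 gives 2700 nM and compound 2 gives 70100 nM. The change between them is 3-hydroxypropyl in place of cyclopentyl on a nitrogen on an aromatic ring, and it costs potency heavily: a 26-fold higher number from compound 1 to compound 2 (1.41 log units; beyond the scatter).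

Compound 3 `N#Cc1ccc(Nc2nc(NC3CCCC3)c3ccccc3n2)cc1` carries a different core, and how that core differs from the core of compound 1 is not broken down here. For compound 3 the entry in this assay reads "not determined" (no result reported), so it has no single number to lean on. Compound 4 `N#Cc1ccc(Nc2nc(NCCCO)c3ccccc3n2)cc1` is the not yet measured partner of compound 3, and the change from compound 3 to compound 4 is 3-hydroxypropyl in place of cyclopentyl on a nitrogen on an aromatic ring. The place of the change is described in the same words for both pairs, so this is the same change made twice among the compounds shown, once on each core.

With no number for compound 3, the only anchor is the measured pair, where the same change gave a 26-fold higher number from compound 1 to compound 2 (1.41 log units; beyond the scatter). For compound 4 the expectation is therefore a weak inhibitor of growth, with much uncertainty, and the estimated value is 60000 nM, expected to fall roughly between 8000 nM and 300000 nM, with a real chance that only a limit and no number is reported.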

Compound 4, concentration for 50% growth inhibition: 2790 nM
Estimate against measurement, compound 4: 22-fold (1.33 log units) above, and the stated range ends above it.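

Among the compounds shown here, with no single number for compound 3, no step from compound 3 to compound 4 can be read, so the result for compound 4 stands alone. The compounds shown leave open whether swapping cyclopentyl for 3-hydroxypropyl costs as much on the core of compound 3 as on the core of compound 1. No supporting data are available to explain the value of compound 4.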